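A few compounds are considered here, and "the series" means these few. Any claim that something is new, unique, unknown or untested is made for them only; others in the source may bear on it.

Compound 1 `O=C(Nc1cccc(-n2cc(-c3ccncc3)c(-c3ccc(Cl)c(O)c3)n2)c1)Nc1cccc(C(F)(F)F)c1`: > 32500 nM
Compound 2 `COc1cc(-c2nn(-c3cccc(NC(=O)Nc4cc(C(F)(F)F)cc(C(F)(F)F)c4)c3)cc2-c2ccncc2)ccc1Cl`: 2730 nM

Going by the values given here, compound 2 stands at 2730 nM in a functional assay on UO-31 cells (Homo sapiens) for inhibition, read by sulforhodamine B assay, with a stated time of 48 h (a higher number here means that more compound is tolerated, a lower number that less compound is tolerated), the only number given there. Compound 1 reaches only a limit in this assay, > 32500 nM, which is the point described by the limit of > 32500 nM in this assay, at which 1 of the 2 values shown sits. Compound 3 `O=C(Nc1cccc(-n2cc(-c3ccncc3)c(-c3ccc(Cl)c(O)c3)n2)c1)Nc1cc(C(F)(F)F)cc(C(F)(F)F)c1` is not yet measured. It differs from compound 2 by hydrogen in place of methyl on an oxygen on an aromatic ring. Among the compounds with values here, no step between measured compounds is available, so the size of this change rests on indirect evidence. Compound 1 carries the same hydroxy and sits only at its limit in this assay. A loss of tolerated concentration beyond the usual scatter is therefore expected for the step from compound 2 to compound 3, a 2.9-fold higher number from compound 2 to compound 3 (0.47 log units; beyond the scatter). Compound 3 is estimated at 8000 nM, with a range from 2500 nM to 32500 nM.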

Compound 3, concentration lethal to 50% of the cells: 6600 nM
Compound 3: middle estimate off by 1.2-fold (0.08 log units), on the high side; the range from low to high includes it.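

In this assay, the exchange of methoxy for hydroxy now has a direct reading, with a 2.4-fold higher number from compound 2 to compound 3 (0.38 log units; beyond the scatter), so the methyl on this oxygen makes a modest difference, and the compound that keeps it carries the lower number. With the hydroxy held fixed, trifluoromethyl in place of hydrogen on an aromatic carbon also counts, with an at least 4.9-fold lower number from compound 1 to compound 3 (0.69 log units; beyond the scatter). The size of this second step is only a bound, as compound 1 stands at a limit: the limit of > 32500 nM in this assay, at which 1 of the 3 values shown sits.

The compounds shown leave open how an ethyl group or a longer chain on this oxygen, or an amine in place of the hydroxy, would read in this assay. Going by these compounds alone, they also leave open whether the exchange keeps its size with a single trifluoromethyl, as the only direct reading comes from the pair compound 2 and compound 3.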